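This account rests on a few compounds, and the source may have more. Where it says the series, first, only, none or still open, it means among the compounds named here.

Compound 1 `CCCC#Cc1cn([C@H]2C[C@H](O)[C@@H](CO)O2)c(=O)[nH]c1=O`: > 200000 nM (a limit)
Compound 2 `CCC#Cc1cn([C@H]2C[C@H](O)[C@@H](CO)O2)c(=O)[nH]c1=O`: > 200000 nM (a limit)

These values come from an ADME assay on L1210/0 cells (Mus musculus) for cytotoxicity, with a stated time of 48 h (a higher number here means a weaker inhibitor, a lower number a stronger inhibitor), where the read-out is a half-maximal inhibitory concentration. Compound 2 has no exact number here, since its > 200000 nM is only a limit of the assay. It shares this position with compound 1, as the limit of > 200000 nM in this assay, at which 2 of the 2 values shown sit, shows.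

The next compound, compound 3 `CCCCCCc1cn([C@H]2C[C@H](O)[C@@H](CO)O2)c(=O)[nH]c1=O`, carries hexyl in place of but-1-yn-1-yl on an aromatic carbon. The triple bond outside aromatic rings therefore leaves.

Within the data shown here, only one measured step bears on this change, a step that the two limits leave unreadable from compound 1 to compound 2. Its size cannot be read, and both of its compounds keep the triple bond, so it offers no size to carry over. With no exact number to build on, no clear change in this assay is expected, and another limit is the likeliest report. The expected step is a number no higher from compound 2 to compound 3 (the limit leaves the size open). Compound 3 is estimated at 200000 nM, with an expected range of 80000 nM to 400000 nM.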

Compound 3, half-maximal inhibitory concentration: > 200000 nM
Compound 3: no number, only a limit; the forecaster's own chance of this, stated with the estimate: 70%; the middle value sits exactly at the limit.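

No step can be read among compound 1, compound 2 and compound 3, as all three stand at the same limit: the limit of > 200000 nM in this assay, at which 3 of the 3 values shown sit.

The compounds shown leave open how strongly any of the three acts in this assay, and whether hexyl, but-1-yn-1-yl and pent-1-yn-1-yl differ from one another there at all.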